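From indole to indazole on the shared core

The source may hold more compounds than are shown below. What is called first, only, known or untested is meant among the compounds shown, and "the series" means these compounds.

Within the data shown here, in a functional assay on DU-145 cells (Homo sapiens) for inhibition, read by trypan blue exclusion, with a stated time of 72 h (on this read-out lower numbers stand for stronger inhibition and higher numbers for weaker inhibition), compound 3 `Cn1c(=O)c(S(=O)(=O)c2ccc(F)cc2)cc2cnc(Nc3ccc4[nH]ccc4c3)nc21` gives 300 nM, the lowest of the three numbers measured so far. Compound 1 `Cn1c(=O)c(S(=O)(=O)c2ccc(F)cc2)cc2cnc(Nc3ccc4cc[nH]c4c3)nc21` gives 10000 nM. Compound 4 `Cn1c(=O)c(S(=O)(=O)c2ccc(F)cc2)cc2cnc(Nc3ccc4[nH]ncc4c3)nc21` has not yet been measured, and it departs from compound 3 in one place: 1H-indazol-5-yl in place of 1H-indol-5-yl on a nitrogen on an aromatic ring. In words, 1H-indazol-5-yl stands in place of 1H-indol-5-yl on a nitrogen on an aromatic ring.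

Among the measured compounds shown here, no measured step isolates this exchange. The nearest evidence is the step of a 33-fold lower number from compound 1 to compound 3 (1.52 log units; beyond the scatter), in which 1H-indol-5-yl replaces 1H-indol-6-yl at the same place. It shows that this assay can respond strongly to a change in this group. Compound 2 `Cn1c(=O)c(S(=O)(=O)c2ccc(F)cc2F)cc2cnc(Nc3ccc4[nH]ncc4c3)nc21` also carries 1H-indazol-5-yl and gives 30000 nM, a far higher number than compound 3 gives. However, compound 2 has a different sulfonyl aryl group, so its value is only an indirect guide. On the evidence of compound 2 at 30000 nM, a clear move towards weaker inhibition is expected, with wide uncertainty. The expected size is a 10-fold higher number from compound 3 to compound 4 (1.00 log units; beyond the scatter). For compound 4 the estimated value is 3000 nM. The expected range for compound 4 runs from 500 nM to 15000 nM.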

Compound 4, half-maximal inhibitory concentration: 5000 nM
For compound 4 the middle estimate is 1.7-fold (0.22 log units) below the measured one; measured number inside the range.
By their numbers in this assay, from the lowest: compound 3; then compounds 4 and 1 (each within the scatter of the next); then compound 2.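

In this assay the exchange at this place now has a step of its own, a 17-fold higher number from compound 3 to compound 4 (1.22 log units; beyond the scatter), so 1H-indazol-5-yl, with its 1 hydrogen-bond acceptor, does not carry over the low number of 1H-indol-5-yl, which has 0 such acceptors. The second step, a 6.0-fold lower number from compound 2 to compound 4 (0.78 log units; beyond the scatter), shows that hydrogen in place of fluoro on an aromatic carbon of the sulfonyl aryl group also moves the number beyond the scatter, so compound 2 had been reflecting more than the indazole alone. The third step, a 2.0-fold lower number from compound 1 to compound 4 (0.30 log units; within the scatter), lies within the scatter, so 1H-indazol-5-yl and 1H-indol-6-yl cannot be told apart here, and among the three groups seen at this place with this sulfonyl aryl group, only 1H-indol-5-yl stands clear of the other two.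

Nothing available explains the size of these steps. On these data alone, it remains open whether a methyl group on the ring nitrogen of 1H-indol-5-yl would hold the number of compound 3, and whether a chloro group in place of the fluoro would shift it.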